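Swapping Methoxy for Methyl: A Second Look

This account rests on a few compounds, and the source may have more. Where it says the series, first, only, none or still open, it means among the compounds named here.

Compound 1, `COc1ncnc2c1c(-c1ccoc1)cn2[C@@H]1O[C@H](CO)[C@@H](O)[C@H]1O`, gives 190 nM in a functional assay on K562 cells (Homo sapiens), read by MTT assay, with a stated time of 72 h; on this read-out higher numbers stand for weaker inhibition and lower numbers for stronger inhibition. Compound 2, `Cc1ncnc2c1c(-c1ccoc1)cn2[C@@H]1O[C@H](CO)[C@@H](O)[C@H]1O`, differs from it by methyl in place of methoxy on an aromatic carbon. In this assay compound 2 reaches only the limit > 20000 nM, which is a boundary of the assay rather than a number (the limit of > 20000 nM in this assay, at which 1 of the 3 values shown sits). The change therefore made an at least 100-fold higher number from compound 1 to compound 2 (2.02 log units; beyond the scatter).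

Compound 3, `COc1ncnc2c1c(-c1cccs1)cn2[C@@H]1O[C@H](CO)[C@@H](O)[C@H]1O`, differs from compound 1 by thiophen-2-yl in place of furan-3-yl on an aromatic carbon, and in this assay compound 3 gives 70 nM, which is a 2.7-fold lower number from compound 1 to compound 3 (0.43 log units; beyond the scatter).

Compound 4, `Cc1ncnc2c1c(-c1cccs1)cn2[C@@H]1O[C@H](CO)[C@@H](O)[C@H]1O`, has not yet been measured. It differs from compound 3 by methyl in place of methoxy on an aromatic carbon, the same change that leads from compound 1 to compound 2, at a place described in the same words, on a core that differs only by thiophen-2-yl in place of furan-3-yl on an aromatic carbon.

The step is expected to be a 140-fold higher number from compound 3 to compound 4 (2.15 log units; beyond the scatter), matching in size the earlier change because an at least 100-fold higher number from compound 1 to compound 2 (2.02 log units; beyond the scatter) is the only measured case of this change. Compound 4 is thus expected to give about 10000 nM in this assay, likely between 2500 nM and 40000 nM, with a real chance that only a limit is reported.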

Compound 4, half-maximal inhibitory concentration: > 20000 nM
Compound 4 gave a limit, no number; the forecaster's own chance of this, stated with the estimate: 45%; middle value at least 2.0-fold (0.30 log units) away from the limit.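

Carried to the core of compound 3, methyl in place of methoxy again sharply weakens inhibition in this assay: the change gives an at least 280-fold higher number from compound 3 to compound 4 (2.45 log units; beyond the scatter). The large loss seen on the core of compound 1 therefore appears on the core of compound 3 as well, but the true size of each loss is unknown and the two cannot be ranked: the same change on two cores in this assay, an at least 100-fold higher number (2.02 log units; beyond the scatter) from compound 1 to compound 2 and an at least 280-fold higher number (2.45 log units; beyond the scatter) from compound 3 to compound 4; the limit leaves it open whether they differ

Compound 2 and compound 4 both end at a limit and not at a number, so the step between them cannot be read, and two cores are too few to speak for any wider set of compounds: the limit of > 20000 nM in this assay, at which 2 of the 4 values shown sit.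

As far as these compounds go, how an amine or an ethoxy group in place of methoxy would read in this assay stays open, so these compounds cannot say what about the methoxy group matters. From the compounds shown here alone, whether the same steep loss holds on a core carrying phenyl in place of thiophen-2-yl also stays open.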